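The source may hold more compounds than are shown below. What is called first, only, known or untested is meant among the compounds shown, and "the series" means these compounds.

Compound 2 `Cc1ccc2c(C3CCN(CCN4CCN(C(C)C)C4=O)CC3)c[nH]c2c1` gives 27 nM in an assay on cell membranes for displacement of a labelled ligand from Adrenergic receptor alpha-1 (Rattus norvegicus); on this read-out higher numbers stand for weaker inhibition and lower numbers for stronger inhibition. Among the three measured members it stands second highest: compound 3 `CC(C)N1CCN(CCN2CCC(c3c[nH]c4cc(Cl)ccc34)CC2)C1=O` gives 34 nM, and the step of a 1.3-fold higher number from compound 2 to compound 3 (0.10 log units; within the scatter) lies within the scatter, while compound 1 `CC(C)N1CCN(CCN2CCC(c3cn(-c4ccc(F)cc4)c4cc(F)ccc34)CC2)C1=O` gives 13 nM, a lower number beyond the scatter. Compound 4 `Cc1ccc2c(C3CCN(CCN4CCN(C(C)C)C4=O)CC3)cn(-c3cccc(F)c3)c2c1` arises from compound 2 by 3-fluorophenyl in place of hydrogen on an aromatic nitrogen. For the measured compounds named here, no measured step changes only this position; the single measured step, a 1.3-fold higher number from compound 2 to compound 3 (0.10 log units; within the scatter), concerns another place. Going by the values given here, compound 1 is the only member carrying an aryl group on that nitrogen. Because compound 1 gives 13 nM, a modest lowering is expected for compound 4, a 1.8-fold lower number from compound 2 to compound 4 (0.26 log units; within the scatter). Compound 4 is expected to give 15 nM, between 6 nM and 40 nM.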

Compound 4, half-maximal inhibitory concentration: 670 nM
Beside the measured number, compound 4's estimate is 45-fold (1.65 log units) below it, outside the stated range (above it).
By their numbers in this assay, from the lowest: compound 1; then compounds 2 and 3 (each within the scatter of the next); then compound 4.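

In this assay the aromatic nitrogen proves highly sensitive to this change, with 3-fluorophenyl in place of hydrogen giving a 25-fold higher number from compound 2 to compound 4 (1.39 log units; beyond the scatter). An aryl group there therefore does not by itself secure a low number: compound 1 also carries one and gives 13 nM but differs from compound 4 in more than one place, so the two cannot be compared directly. Nothing available accounts for the rise. Open, from the compounds shown here alone, is whether the rise is specific to 3-fluorophenyl on this core or extends to other groups on that nitrogen. An ethyl or benzyl group there would test this.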